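The compounds below may be only part of what the source reports. "The series", "measured", "known", "first", "only" and "open" are said of these compounds alone.

Measured so far in a functional assay with Melanocortin receptor 4 (Homo sapiens) as the target, read by cAMP accumulation; on this read-out lower numbers stand for an effect already at smaller amounts and higher numbers for an effect only at larger amounts of compound:
compound 1 `COc1ccc(-n2nc(Sc3ccc(Cl)cc3)cc(CC[C@@H](C)NC(=O)[C@H]3CNCC[C@@H]3c3cccc(Cl)c3)c2=O)cc1` — 680 nM
compound 2 `COc1ccc(-n2nc(Sc3ccc(Cl)cc3)cc(CC[C@@H](C)NC(=O)[C@H]3CNC[C@@H]3c3ccccc3F)c2=O)cc1` — 710 nM

Compound 2 and compound 1 give two numbers within the scatter of each other, so neither reads as different from the other in this assay.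

Compound 3 `COc1ccc(-n2nc(Sc3ccc(Cl)cc3)cc(CC[C@@H](C)NC(=O)[C@H]3CNC[C@@H]3c3ccc(C)cc3)c2=O)cc1` takes from compound 2 the change 4-methylphenyl in place of 2-fluorophenyl on a saturated ring carbon — 4-methylphenyl in place of 2-fluorophenyl on a saturated ring carbon. Within the data shown here, no measured pair shows this exchange, so the step it brings is open. For compound 3 the expected outcome is a step of a 1.1-fold higher number from compound 2 to compound 3 (0.05 log units; within the scatter) that stays within the scatter, with no clear direction. Compound 3 is therefore estimated at 800 nM, in the range 300 nM to 2500 nM.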

Compound 3, half-maximal effective concentration: 750 nM
Compound 3: middle estimate off by 1.1-fold (0.03 log units), on the high side; measured number inside the range.
By their numbers in this assay, from the lowest: compounds 1, 2 and 3 (each within the scatter of the next).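

In this assay, 4-methylphenyl in place of 2-fluorophenyl on the saturated ring carbon gives a 1.1-fold higher number from compound 2 to compound 3 (0.02 log units; within the scatter), so at this position the two aryl groups cannot be told apart. The exchange alters both the substituent and its place on the phenyl ring, and the pair cannot separate those two parts. No measurement at hand bears on this result.

Still open, going by these compounds, is whether a phenyl ring carrying an amine or a carboxylic acid would give a step beyond the scatter. The same question stands for a pyridine ring in place of the phenyl ring.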